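The compounds below may be only part of what the source reports. "The series", "measured", "known", "first", "only" and "open" are said of these compounds alone.

Measured in a functional assay on K562 cells (Homo sapiens) for inhibition, read by trypan blue exclusion, with a stated time of 72 h; on this read-out higher numbers stand for weaker inhibition and lower numbers for stronger inhibition:
- Compound 1 `Cn1c(=O)c(S(=O)(=O)c2ccccc2)cc2cnc(Nc3ccc4ncccc4c3)nc21`: 100000 nM
- Compound 2 `Cn1c(=O)c(S(=O)(=O)c2ccccc2)cc2cnc(Nc3cnc4[nH]ccc4c3)nc21`: 5000 nM
- Compound 3 `Cn1c(=O)c(S(=O)(=O)c2ccccc2)cc2cnc(Nc3ccc4cc[nH]c4c3)nc21`: 10000 nM

Compound 2 and compound 3 share the low end of these numbers, and a 2.0-fold higher number from compound 2 to compound 3 (0.30 log units; within the scatter) lies within the scatter. Compound 1 stands apart, with a 20-fold lower number from compound 1 to compound 2 (1.30 log units; beyond the scatter) and a 10-fold lower number from compound 1 to compound 3 (1.00 log units; beyond the scatter), both beyond the scatter.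

The next compound, compound 4 `Cc1ccc(S(=O)(=O)c2cc3cnc(Nc4cnc5[nH]ccc5c4)nc3n(C)c2=O)cc1`, differs from compound 2 at a single spot: methyl in place of hydrogen on an aromatic carbon. This turns phenylsulfonyl into (4-methylphenyl)sulfonyl. All three measured steps swap the group on the nitrogen and leave the phenylsulfonyl untouched, so none of them tests this change directly. Going by the values given here, they show only that a change elsewhere in the molecule can move the number a long way. Among the compounds with values here, with no measured step at the phenylsulfonyl, no step beyond the scatter is expected in this assay. The estimated step is no change at the digits printed from compound 2 to compound 4 (within the scatter). For compound 4 the expected value is 5000 nM, with an estimated range of 1800 nM to 14000 nM.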

Compound 4, half-maximal inhibitory concentration: 15000 nM
For compound 4 the middle estimate is 3.0-fold (0.48 log units) below the measured one; the measured number lies above the stated range.
By their numbers in this assay, from the lowest: compounds 2, 3 and 4 (each within the scatter of the next, the first and the last beyond it); then compound 1.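

The phenylsulfonyl end of the molecule is not a silent part of it: in this assay, one methyl on the aromatic carbon para to a large group gives a 3.0-fold higher number from compound 2 to compound 4 (0.48 log units; beyond the scatter) and so weaker inhibition. Going by these compounds alone, this is the first measured change at this position, and even a single added carbon here moves the result by more than repeat measurements normally would, although the step is much smaller than the largest one seen on swapping the group on the nitrogen. Nothing measured here explains why this methyl weakens inhibition.

On these data alone, how a chlorine atom, a methoxy group or an amine at this same place would compare remains open. Also open, as far as these compounds go, is whether adding the methyl would shift the number in the same direction in compound 1 or compound 3, which carry other groups on the nitrogen.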